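The compounds below may be only part of what the source reports. "The series", "measured", "known", "first", "only" and "open" are said of these compounds alone.

In a functional assay on HeLa cells (Homo sapiens) for inhibition (on this read-out higher numbers stand for weaker inhibition and lower numbers for stronger inhibition), the compounds gathered here share one core and differ only in the aryl groups attached to it. Compound 1 `Oc1cccc(-c2cc(-c3ccc(F)cc3)cc(-c3ccccc3O)n2)c1` gives > 50000 nM, a limit of the assay rather than a number. Compound 2 `Oc1ccc(-c2cc(-c3ccc(F)cc3)cc(-c3ccccc3O)n2)cc1` likewise gives > 50000 nM, again a limit. The change between them is 4-hydroxyphenyl in place of 3-hydroxyphenyl on an aromatic carbon, and the step amounts to a step that the two limits leave unreadable from compound 1 to compound 2 because both sit at the limit of > 50000 nM in this assay, at which 2 of the 3 values shown sit. Among the measured compounds shown here, compound 3 `Oc1cccc(-c2cc(-c3ccccc3C(F)(F)F)cc(-c3ccccc3O)n2)c1` is the one member that returns a number, giving 16800 nM in this assay. Its core differs from that of compound 1 by 2-(trifluoromethyl)phenyl in place of 4-fluorophenyl on an aromatic carbon, and that change produced an at least 2.9-fold lower number from compound 1 to compound 3 (0.47 log units; beyond the scatter). Compound 4 `Oc1ccc(-c2cc(-c3ccccc3C(F)(F)F)cc(-c3ccccc3O)n2)cc1` is not yet measured; it differs from compound 3 by 4-hydroxyphenyl in place of 3-hydroxyphenyl on an aromatic carbon. For the measured compounds named here, this is the same kind of change as the one from compound 1 to compound 2, though the surroundings are not the same: in the first pair the place is meta to a 2-hydroxyphenyl group and meta to a 4-fluorophenyl group, whereas in the second pair it is meta to a 2-(trifluoromethyl)phenyl group and meta to a 2-hydroxyphenyl group. The earlier step gives no readable size, so the expectation rests on compound 3 alone at 16800 nM. Compound 4 is expected to give about 25000 nM, within a range from 8000 nM to 60000 nM. That estimate implies an expected step of a 1.5-fold higher number from compound 3 to compound 4 (0.17 log units; within the scatter).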

Compound 4, half-maximal inhibitory concentration: 16500 nM
Beside the measured number, compound 4's estimate is 1.5-fold (0.18 log units) above it, within the range that was stated.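

On the core that carries the 2-(trifluoromethyl)phenyl group, 4-hydroxyphenyl in place of 3-hydroxyphenyl gives a 1.0-fold lower number from compound 3 to compound 4 (0.01 log units; within the scatter) in this assay, so on this core the change leaves no readable difference. The other change, 2-(trifluoromethyl)phenyl in place of 4-fluorophenyl, now also appears on the core with the 4-hydroxyphenyl group, where it gives an at least 3.0-fold lower number from compound 2 to compound 4 (0.48 log units; beyond the scatter), so it lowers the number on both cores, though its size on each stays open: the same change on two cores in this assay, an at least 2.9-fold lower number (0.47 log units; beyond the scatter) from compound 1 to compound 3 and an at least 3.0-fold lower number (0.48 log units; beyond the scatter) from compound 2 to compound 4; the limit leaves it open whether they differ The hydroxyphenyl change, by contrast, cannot be compared between cores, since the step from compound 1 to compound 2 cannot be read, and nothing here shows whether its flat result on the second core would hold on the first: the limit of > 50000 nM in this assay, at which 2 of the 4 values shown sit.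

The compounds shown leave open how the number would respond to a methoxy group, an amine or a carboxylic acid in place of the hydroxyl on either hydroxyphenyl group. They also leave open whether 4-(trifluoromethyl)phenyl or 2-fluorophenyl would act as 2-(trifluoromethyl)phenyl does, which would separate the identity of the group from where it sits on its ring.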